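Relocating the Chlorine on the Phenyl Ring

A few compounds are considered here, and "the series" means these few. Any claim that something is new, unique, unknown or untested is made for them only; others in the source may bear on it.

Among the measured compounds shown here, compound 2 `CN(CCNCc1cn(-c2ccc(Cl)cc2)nn1)CCNc1ccnc2cc(Cl)ccc12` holds the lowest of the two numbers measured so far. In a functional assay on NCI-H460 cells (Homo sapiens) for antiproliferative activity, read by sulforhodamine B assay, with a stated time of 72 h (a lower number here means a stronger inhibitor, a higher number a weaker inhibitor), compound 2 gives 14000 nM. For the measured compounds named here, its one neighbour, compound 1 `CN(CCNCc1cn(-c2ccc(F)cc2)nn1)CCNc1ccnc2cc(Cl)ccc12`, gives 34000 nM in this assay. Going by the values given here, the single step between them, a 2.4-fold lower number from compound 1 to compound 2 (0.39 log units; beyond the scatter), is the only measured change available.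

Compound 3 `CN(CCNCc1cn(-c2cccc(Cl)c2)nn1)CCNc1ccnc2cc(Cl)ccc12` keeps every atom of compound 2 and changes only how they are joined: 3-chlorophenyl in place of 4-chlorophenyl on an aromatic nitrogen. That measured step does not bear directly on this change, since it swapped one halogen for another, whereas here the same chlorine is relocated on the ring. With no measured guide, the expectation for compound 3 is a step of no more than the scatter, no change at the digits printed from compound 2 to compound 3 (within the scatter). The estimate for compound 3 in this assay is therefore 14000 nM, within a range from 5000 nM to 40000 nM.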

Compound 3, half-maximal inhibitory concentration: 17000 nM
Compound 3: the middle estimate sits 1.2-fold (0.08 log units) below what was measured; the range from low to high includes it.
By their numbers in this assay, from the lowest: compounds 2, 3 and 1 (each within the scatter of the next, the first and the last beyond it).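

Moving the chlorine from 4-chlorophenyl to 3-chlorophenyl on the aromatic nitrogen gives a 1.2-fold higher number from compound 2 to compound 3 (0.08 log units; within the scatter) in this assay and so leaves these two placements of the chlorine indistinguishable in this measurement. The comparison with the fluorine-bearing compound gives a 2.0-fold lower number from compound 1 to compound 3 (0.30 log units; within the scatter) and so places compound 3 within the scatter of both neighbours, although compound 1 and compound 2 lie beyond the scatter of each other. No supporting measurement is available to explain these results.

The compounds shown leave open whether a different group on this phenyl ring, such as a methoxy, a trifluoromethyl or a nitrile, would move the number beyond the scatter. They also leave open what would happen if a butyl chain took the place of the whole ring on the aromatic nitrogen.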